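A Spiro Scaffold Series: Swapping the Triazole Aryl Group

The source may hold more compounds than are shown below. What is called first, only, known or untested is meant among the compounds shown, and "the series" means these compounds.

Of the compounds shown here, two built on one shared core have been tested in a functional assay on A549 cells (Homo sapiens) for antiproliferative activity, read by MTT assay, with a stated time of 48 h; on this read-out higher numbers stand for weaker inhibition and lower numbers for stronger inhibition. Compound 1, with structure `N#CC1=C(N)Oc2c(c3nc4ccccc4nc3c3ccccc23)C12C(=O)N(Cc1cnnn1-c1ccc(Br)cc1)c1ccccc12`, gives 44300 nM in this assay. Compound 2, with structure `CC(=O)Nc1ccc(-n2nncc2CN2C(=O)C3(C(C#N)=C(N)Oc4c(N)cc5nc6ccccc6nc5c43)c3ccccc32)cc1`, returns only a limit in this assay, namely > 50000 nM, so no number is known for it. This places compound 2 at the weak end of what can be reported, as the limit of > 50000 nM in this assay, at which 1 of the 2 values shown sits, shows. Compound 3, with structure `CCc1cccc(CC)c1-n1nncc1CN1C(=O)C2(C(C#N)=C(N)Oc3c(N)cc4nc5ccccc5nc4c32)c2ccccc21`, has not yet been measured. It differs from compound 2 in one place: 2,6-diethylphenyl in place of 4-acetamidophenyl on an aromatic nitrogen. For the measured compounds named here, no step between measured compounds is available to guide the expectation, and both results shown sit at weak inhibition. Compound 3 is expected to stay in that weak region. The step that this estimate means, an at least 1.1-fold lower number from compound 2 to compound 3 (0.04 log units; that floor lies within the scatter), is expected to be no larger than the scatter. Compound 3 is estimated at 45000 nM in this assay, with a range from 15000 nM to 150000 nM.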

Compound 3, half-maximal inhibitory concentration: > 50000 nM
Compound 3 gave a limit, no number (the forecaster's own chance of this, stated with the estimate: 55%); at least 1.1-fold (0.04 log units) between middle value and limit.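

Compound 2 and compound 3 both give only a limit rather than a number, so no step can be read between them. From the compounds shown here alone, it stays open how 2,6-diethylphenyl and 4-acetamidophenyl truly compare, and whether any other group in that place would give clearly stronger inhibition.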